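This account rests on a few compounds, and the source may have more. Where it says the series, first, only, none or still open, it means among the compounds named here.

Within the data shown here, only two compounds have been measured so far. In a functional assay on HCT-116 cells (Homo sapiens) for antiproliferative activity (a higher number here means a weaker inhibitor, a lower number a stronger inhibitor), compound 1 (`CC[C@H](C)[C@H]1C(=O)N[C@H](Cc2ccc(O)c(Br)c2)C(=O)N[C@@H](C(C)(C)O)C(=O)O[C@H](c2ccccc2)[C@H](C)/C=C/C=C(\C)[C@H](OC)C/C=C(\C)C(=O)N1C`) gives 3.88 nM and compound 2 (`CC[C@H](C)[C@H]1C(=O)N[C@H](Cc2cc(Cl)c(O)c(Cl)c2)C(=O)N[C@@H](C(C)C)C(=O)O[C@H](c2ccccc2)[C@H](C)/C=C/C=C(\C)[C@H](OC)C[C@@H]2O[C@@]2(C)C(=O)N1C`) gives 4.25 nM as its value. These two values lie within the scatter of each other, so compound 2 stands level with compound 1. Among the measured compounds shown here, the two compounds differ in more than one place, and no measured pair isolates a single change.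

Compound 3 (`CC[C@H](C)[C@H]1C(=O)N[C@H](Cc2ccc(O)c(Br)c2)C(=O)N[C@@H](C(C)C)C(=O)O[C@H](c2ccccc2)[C@H](C)/C=C/C=C(\C)[C@H](OC)C[C@@H]2O[C@@]2(C)C(=O)N1C`) has not yet been measured. It departs from compound 2 in one place, on a saturated chain carbon bound to a saturated ring carbon: 3-bromo-4-hydroxyphenyl in place of 3,5-dichloro-4-hydroxyphenyl on a saturated chain carbon bound to a saturated ring carbon. The entering 3-bromo-4-hydroxyphenyl group already occurs in compound 1, which at 3.88 nM in this assay gives no sign of a separation from compound 2. From the compounds shown here alone, no change beyond the scatter is therefore expected in this assay, and the direction remains open. The expected size is a 1.1-fold lower number from compound 2 to compound 3 (0.05 log units; within the scatter) in this estimate. In this assay compound 3 is estimated at 3.8 nM within a range of 1.3 nM to 11 nM for the coming measurement.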

Compound 3, half-maximal inhibitory concentration: 3.93 nM
The estimate for compound 3 lay 1.0-fold (0.01 log units) below the measured number; measured number inside the range.
By their numbers in this assay, from the lowest: compounds 1, 3 and 2 (each within the scatter of the next).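

In this assay, among these compounds, the exchange at this place, on a saturated chain carbon bound to a saturated ring carbon, can now be read on its own for the first time (a 1.1-fold lower number from compound 2 to compound 3 (0.03 log units; within the scatter)). The earlier pair differed in more than one place and could not isolate it. With the rest of the structure held constant, 3,5-dichloro-4-hydroxyphenyl and 3-bromo-4-hydroxyphenyl stand level in this assay, so this particular exchange of chlorine-bearing for bromine-bearing aryl group leaves the antiproliferative read-out within the scatter, and nothing available offers an explanation for this result.

The compounds shown leave open whether this place tolerates groups of a different kind, such as a phenyl ring carrying no halogen or one carrying an amine or a carboxylic acid in place of the halogen. From the compounds shown here alone, they also do not separate the other places in which compound 1 departs from compound 3, so the contribution of each of those changes to the read-out remains unknown.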